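This account rests on a few compounds, and the source may have more. Where it says the series, first, only, none or still open, it means among the compounds named here.

In a functional assay on QGY cells (Homo sapiens) for cytotoxicity, read by MTT assay, with a stated time of 48 h (a higher number here means a weaker inhibitor, a lower number a stronger inhibitor), compound 1 `COc1cc([C@@H]2C[C@@]2(CO)C(=O)Nc2ccccc2)cc(OC)c1OC` gives 36700 nM. Compound 2 `CCOC(=O)[C@@]1(C(=O)Nc2ccccc2)C[C@@H]1c1cc(OC)c(OC)c(OC)c1` returns no number, only a limit: > 100000 nM. That figure is a limit and not a measurement, so the position of compound 2 is known only up to that point.

The next compound to be read is compound 3 `COc1cc([C@H]2C[C@@]2(CO)C(=O)Nc2ccccc2)cc(OC)c1OC`. Compared with compound 2, it carries hydroxymethyl in place of ethoxycarbonyl on a saturated ring carbon, next to the ring atom that bears a large group (hydroxymethyl in place of ethoxycarbonyl on a saturated ring carbon). Within the data shown here, no measured pair isolates this change, so its size in this assay cannot be read directly. The nearest guide is compound 1, which also bears hydroxymethyl and gives 36700 nM. Compound 3 is not the same structure as compound 1, however, so that value is only a guide and the range has to stay wide. A move toward stronger inhibition is expected, and the estimated change is an at least 2.5-fold lower number from compound 2 to compound 3 (0.39 log units; beyond the scatter). Compound 3 is expected to come in at about 40000 nM, with an estimated range from 12000 nM to 100000 nM.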

Compound 3, half-maximal inhibitory concentration: > 100000 nM
Compound 3: only a limit was reported; the forecaster's own chance of this, stated with the estimate: 25%; at least 2.5-fold (0.39 log units) between middle value and limit.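

In this assay, compound 3 gives only > 100000 nM, and this value is a limit of the assay, not a number. Even so, the result shows that hydroxymethyl on this saturated ring carbon does not by itself give a measured value, as the change of one drawn stereocentre produces an at least 2.7-fold higher number from compound 1 to compound 3 (0.43 log units; beyond the scatter), so the configuration at this carbon matters in this assay as well as the group it carries. This comparison isolates configuration as the cause of that step, because nothing else separates the pair: the fact that compounds 1 and 3 differ only in the configuration as drawn

The step for hydroxymethyl in place of ethoxycarbonyl cannot be read between compound 2 and compound 3, and how far compound 3 lies past its limit also stays unknown, because both values rest on the same limit: the limit of > 100000 nM in this assay, at which 2 of the 3 values shown sit. The compounds shown also leave open whether an amine or a carboxylic acid on this ring carbon, in either configuration, would give a measured value, and whether the configuration would matter to the same extent with such a group in place.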